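This account rests on a few compounds, and the source may have more. Where it says the series, first, only, none or still open, it means among the compounds named here.

Values in a functional assay on HeLa cells (Homo sapiens) for antiproliferative activity, read by MTT assay, with a stated time of 48 h; on this read-out lower numbers stand for stronger inhibition and higher numbers for weaker inhibition:

Compound 1 `COc1ccc2nc(Nc3ccnc(Nc4ccc(S(N)(=O)=O)cc4)n3)sc2c1`: 1730 nM
Compound 2 `NS(=O)(=O)c1ccc(Nc2ncc(F)c(Nc3nc4ccccc4s3)n2)cc1`: 4520 nM
Compound 3 `Cc1cnc(Nc2ccc(Cl)cc2)nc1Nc1nc2ccccc2s1`: > 50000 nM

Compound 3 returns no number, only a limit, in this assay. Compound 3 thus stands at the limit of > 50000 nM in this assay, at which 1 of the 3 values shown sits, the weakest end of the numbers shown, with compound 1 and compound 2 the only members that give a measured value.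

Compound 4 `Cc1cnc(Nc2ccc(F)cc2)nc1Nc1nc2ccccc2s1` differs from compound 3 by fluoro in place of chloro on an aromatic carbon. Among the measured compounds shown here, no measured pair in the set carries this change, so its size is unknown here; a change of one halogen for another in this position is expected to move the read-out by no more than the usual scatter, in either direction. Compound 4 is therefore expected to sit again near the limit, estimated at 50000 nM with a range of 15000 nM to 150000 nM. The expected step is a number no higher from compound 3 to compound 4 (the limit leaves the size open).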

Compound 4, half-maximal inhibitory concentration: > 50000 nM
Compound 4 ended at the assay's limit; the forecaster's own chance of this, stated with the estimate: 70%; the middle value sits exactly at the limit.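

Compound 3 and compound 4 both give only a limit, so no step between them can be read: the limit of > 50000 nM in this assay, at which 2 of the 4 values shown sit.

The compounds shown leave open whether fluoro in place of chloro on an aromatic carbon changes the read-out at all.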